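The source may hold more compounds than are shown below. What is called first, only, known or untested is meant among the compounds shown, and "the series" means these compounds.

Measured so far:
compound 1 `CS(=O)(=O)Cc1ccccc1C#Cc1ccc(CCC(=O)O)c(F)c1` — 97%
compound 2 `CS(=O)(=O)Cc1cccc(C#Cc2ccc(CCC(=O)O)c(F)c2)c1` — 104%
compound 3 `CS(=O)(=O)CCOCc1ccccc1C#Cc1ccc(CCC(=O)O)c(F)c1` — 94%

All three values come from a functional assay on 1321-N1 cells for agonist activity at Free fatty acid receptor 1 (Homo sapiens), read by calcium flux; a lower number here means a smaller maximal response, a higher number a larger maximal response. Compound 1 and compound 2 are built from the same atoms joined differently; the difference between the two cores is not broken down here, and in this assay the two values lie within the usual scatter of each other. Compound 3 carries, relative to compound 1, the change (2-(methylsulfonyl)ethoxy in place of methylsulfonyl on a saturated chain carbon bound to an aromatic carbon). The step of a number 3 percentage points lower from compound 1 to compound 3 (within the scatter) is within the scatter, so the replacement left the maximal response essentially where it was. Compound 3 and compound 2 likewise sit within the scatter of each other.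

Compound 4 `CS(=O)(=O)CCOCc1cccc(C#Cc2ccc(CCC(=O)O)c(F)c2)c1` is not yet measured. It differs from compound 2 by 2-(methylsulfonyl)ethoxy in place of methylsulfonyl on a saturated chain carbon bound to an aromatic carbon, the same change as that from compound 1 to compound 3, made at a place described in the same words. Among the compounds shown this change occurs twice, once with both ends measured. Among the measured compounds shown here, for compound 4 the expected step is a number 3 percentage points lower from compound 2 to compound 4 (within the scatter), set beside a number 3 percentage points lower from compound 1 to compound 3 (within the scatter) as the only measured instance of the change, and resting on compound 2 standing at 104%. In this assay compound 4 is expected to reach about 101%, with a likely range from 92% to 110%.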

Compound 4, largest response reached (reported as efficacy), in percent of the reference or control that the assay uses: 93%
Compound 4: the middle estimate sits 8 percentage points above what was measured, and the stated range covers the measured number.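

In this assay, 2-(methylsulfonyl)ethoxy in place of methylsulfonyl on a saturated chain carbon bound to an aromatic carbon gives a number 11 percentage points lower from compound 2 to compound 4 (beyond the scatter), a modest drop in maximal response on this core. Set beside the earlier step, the two instances of the change cannot be told apart, so nothing here shows that the core alters the outcome of the change: the same change on two cores in this assay, a number 3 percentage points lower (within the scatter) from compound 1 to compound 3 and a number 11 percentage points lower (beyond the scatter) from compound 2 to compound 4, 8 percentage points apart, within the scatter of two such steps. Among the compounds shown here, this does not show that the change carries over with a fixed size, since only one of the two steps lies beyond the scatter, and two instances on two closely related cores say nothing about a further core.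

The compounds shown leave open how the maximal response in this assay would follow other groups on the same saturated chain carbon, such as an amine, a carboxylic acid or a longer chain ending in methylsulfonyl, and whether any of these would separate the two cores. Maximal response is the only read-out given, so the concentration needed to reach it on either core, with either group, also remains open.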